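Swapping a Hydroxyphenyl Sulfonyl Group for a Small Ring

A few compounds are considered here, and "the series" means these few. Any claim that something is new, unique, unknown or untested is made for them only; others in the source may bear on it.

Three long-chain compounds have been measured in a functional assay on Coronary artery (Bos taurus); on this read-out higher numbers stand for an effect only at larger amounts of compound and lower numbers for an effect already at smaller amounts. Compound 1 (`CCCCCCC(=O)N(CCCC/C=C\CCCCCCC(=O)OCCOCCOCCO)C(C)C`) gives 2900 nM and compound 2 (`CCCCCNC(=O)NCCCC/C=C\CCCCCS(=O)(=O)c1ccccc1O`) gives 5000 nM, two numbers within the usual scatter of each other. Compound 3 (`CCCCNC(=O)C(=O)NCCCC/C=C\CCCCCCc1noc(=S)[nH]1`) gives 360 nM, lower than compound 2 by more than that scatter. Compound 2 therefore stands at the high end of this small set, where more compound is needed for an effect.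

Compound 4 (`CCCCCNC(=O)NCCCC/C=C\CCCCCCc1nsc(=O)[nH]1`) has not yet been measured. It differs from compound 2 in one place: a group of 7 heavy atoms (3 carbon, 2 nitrogen, 1 oxygen, 1 sulfur; one five-membered aromatic ring with 3 hetero atoms) in place of a group of 10 heavy atoms (6 carbon, 3 oxygen, 1 sulfur; one six-membered aromatic ring of carbon only), on a saturated chain carbon, five bonds along the chain from a double-bonded chain carbon. The change sits on a saturated chain carbon, five bonds along the chain from a double-bonded chain carbon. Going by the values given here, no measured pair isolates this swap, so the evidence is indirect. Compound 3 also carries a five-membered aromatic ring and gives 360 nM, which points to a lower number. The expected change is a 5.6-fold lower number from compound 2 to compound 4 (0.74 log units; beyond the scatter), beyond the scatter but uncertain. For compound 4 the estimated value is 900 nM, with an expected range of 200 nM to 4000 nM.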

Compound 4, half-maximal effective concentration: 2400 nM
Beside the measured number, compound 4's estimate is 2.7-fold (0.43 log units) below it; the range from low to high includes it.
By their numbers in this assay, from the lowest: compound 3; then compounds 4, 1 and 2 (each within the scatter of the next, the first and the last beyond it).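

In this assay, going by these compounds alone, this is the first pair in which only this position changes, and the swap gives a 2.1-fold lower number from compound 2 to compound 4 (0.32 log units; beyond the scatter), a modest step. The (2-hydroxyphenyl)sulfonyl group on this saturated chain carbon can therefore give way to a smaller five-membered aromatic ring with 3 hetero atoms without raising the number, even though both groups have the same counts of hydrogen-bond donors and acceptors. No measurement shown here explains why the number moves.

The swap changes the ring and removes the sulfonyl group in a single step, so the compounds shown leave open which of these changes goes with the lower number. A plain phenylsulfonyl group or a carboxylic acid at this place would test whether the hydroxyl group or the ring matters here.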